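A few compounds are considered here, and "the series" means these few. Any claim that something is new, unique, unknown or untested is made for them only; others in the source may bear on it.

Measured so far:
Compound 1, `O=C(OC1(C(=O)Nc2ccc([N+](=O)[O-])cc2)CCCCC1)c1ccccc1I`, gives 396 nM in an ADME assay on WI-38 cells (Homo sapiens) for inhibition, read by MTT assay, with a stated time of 72 h; a higher number here means a weaker inhibitor, a lower number a stronger inhibitor.
Compound 2, `O=C(OC1(C(=O)Nc2ccc([N+](=O)[O-])cc2)CCCCC1)c1ccc([N+](=O)[O-])cc1`, gives 761 nM in this assay.

Within the data shown here, compound 2 stands at one end of these two numbers, but the only measured step, a 1.9-fold higher number from compound 1 to compound 2 (0.28 log units; within the scatter), lies within the scatter, so the two compounds cannot be told apart on this evidence. Compound 3, `O=C(/C=C/c1ccccc1)OC1(C(=O)Nc2ccc([N+](=O)[O-])cc2)CCCCC1`, has not yet been measured. It differs from compound 2 in one place: 2-phenylethenyl in place of 4-nitrophenyl on a carbonyl carbon. This is again an exchange of the group on the carbonyl carbon whose other neighbour is oxygen next to a carbonyl group, the same place that was changed between compound 1 and compound 2, where the step stayed within the scatter. Among the measured compounds shown here, with only that step to go on, no change beyond the scatter is expected in this assay, and the expected step is a 1.3-fold lower number from compound 2 to compound 3 (0.10 log units; within the scatter). Compound 3 is therefore estimated at 600 nM, with an expected range from 250 nM to 1500 nM.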

Compound 3, half-maximal inhibitory concentration: 41 nM
For compound 3 the middle estimate is 15-fold (1.17 log units) above the measured one, and the stated range ends above it.
By their numbers in this assay, from the lowest: compound 3; then compounds 1 and 2 (each within the scatter of the next).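

Among these compounds, the group on this carbonyl carbon can matter a great deal in this assay: 2-phenylethenyl in place of 4-nitrophenyl gives a 19-fold lower number from compound 2 to compound 3 (1.27 log units; beyond the scatter), whereas the only earlier exchange at this place stayed within the scatter. The same group in place of 2-iodophenyl gives a 9.7-fold lower number from compound 1 to compound 3 (0.98 log units; beyond the scatter), so the gain appears against both groups shown, and these two cannot be told apart from each other. No measurement offered here accounts for this difference.

On these data alone, it remains open whether the result depends on the double bond of 2-phenylethenyl, which the saturated 2-phenylethyl group would test, or on the phenyl ring it carries, which a plain methyl group in its place would test. As far as these compounds go, how an amine or a carboxylic acid on that phenyl ring would alter the number also remains unknown.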